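Swapping the aryl group on the amine: compound 3 to compound 4

The compounds below may be only part of what the source reports. "The series", "measured", "known", "first", "only" and "open" are said of these compounds alone.

Of the compounds shown here, three sharing one core have been tested in a functional assay on HeLa cells (Homo sapiens) for inhibition, read by sulforhodamine B assay; on this read-out lower numbers stand for stronger inhibition and higher numbers for weaker inhibition. Compound 1 `O=C1C=C(Nc2cccc(Cl)c2)C(=O)c2c1nc1n2[C@H]2OC[C@@H](O)[C@H]2OC1` gives 6040 nM. Compound 2 `COc1ccc(NC2=CC(=O)c3nc4n(c3C2=O)[C@H]2OC[C@@H](O)[C@H]2OC4)cc1` gives 4780 nM. Compound 3 `CCOc1ccccc1NC1=CC(=O)c2nc3n(c2C1=O)[C@H]1OC[C@@H](O)[C@H]1OC3` gives 6040 nM. On these numbers compound 3 stands level with compound 1, the two together being the highest of the three, while compound 2 is the furthest away, with a step of a 1.3-fold higher number from compound 2 to compound 3 (0.10 log units; within the scatter); every step here lies within the scatter, so none of the three can be called stronger or weaker than another.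

Compound 4 `O=C1C=C(Nc2ccc(Br)cc2)C(=O)c2c1nc1n2[C@H]2OC[C@@H](O)[C@H]2OC1` is not yet measured. It differs from compound 3 in one place: 4-bromophenyl in place of 2-ethoxyphenyl on an amine nitrogen. Among the measured compounds shown here, the steps that bear on this change are those that also swap the aryl group on the amine nitrogen, namely no change at the digits printed from compound 1 to compound 3 (within the scatter) and a 1.3-fold higher number from compound 2 to compound 3 (0.10 log units; within the scatter), and also a 1.3-fold lower number from compound 1 to compound 2 (0.10 log units; within the scatter). None of them moved the number beyond the scatter, so no step beyond the scatter is expected in this assay either, and compound 4 is estimated to show a 1.1-fold lower number from compound 3 to compound 4 (0.04 log units; within the scatter). Compound 4 is therefore expected to give about 5500 nM, with a likely range from 2500 nM to 12000 nM.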

Compound 4, half-maximal inhibitory concentration: 3830 nM
The estimate for compound 4 lay 1.4-fold (0.16 log units) above the measured number; measured number inside the range.
By their numbers in this assay, from the lowest: compounds 4, 2, 1 and 3 (each within the scatter of the next).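

What is new is that 4-bromophenyl, which has bromine and no hydrogen-bond acceptor where 2-ethoxyphenyl has one, still leaves the number in this assay within the scatter, with a 1.6-fold lower number from compound 3 to compound 4 (0.20 log units; within the scatter). The same holds for the comparison with the other two compounds, with a 1.6-fold lower number from compound 1 to compound 4 (0.20 log units; within the scatter) and, for bromo in place of methoxy on an aromatic carbon, a 1.2-fold lower number from compound 2 to compound 4 (0.10 log units; within the scatter). All four aryl groups on the amine nitrogen therefore give numbers that cannot be told apart, so no ranking among them can be drawn from this assay.

Nothing available here bears on the reason for this lack of separation. Going by these compounds, whether an amine or a carboxylic acid on the aryl ring, or a longer chain in its place, would move the number beyond the scatter remains open.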